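An ether side chain in place of an alkyl chain

The compounds below may be only part of what the source reports. "The series", "measured", "known", "first", "only" and "open" are said of these compounds alone.

Compound 1, `CC[C@H](C1CC1)n1c(=O)c(C)nc2c(-c3cc(Cl)c(OC)cc3C)ccnc21`, gives 4.5 nM in a functional assay for antagonist activity at corticotropin-releasing factor receptor 1 (Rattus norvegicus); a higher number here means a weaker inhibitor, a lower number a stronger inhibitor.
Compound 2, `CCC(C1CC1)n1c(=O)c(C)nc2c(-c3cc(Cl)c(OC)cc3OC)ccnc21`, gives 3.4 nM in this assay.
Compound 3, `CCCC(C)n1c(=O)c(C)nc2c(-c3ccc(Cl)cc3Cl)ccnc21`, gives 62 nM in this assay.

Compound 3 stands at the highest number of the three; compound 1 and compound 2 both lie well below it, each beyond the usual scatter. Compound 4, `CC[C@@H](COC)n1c(=O)c(C)nc2c(-c3ccc(Cl)cc3Cl)ccnc21`, differs from compound 3 in one place: 1-(methoxymethyl)propyl in place of 1-methylbutyl on an aromatic nitrogen. Among the compounds with values here, no pair of measured compounds shows this particular change, so its size is not known from these data. A step of modest size toward a lower number, possibly not beyond the scatter, is expected from compound 3 to compound 4, namely a 2.1-fold lower number from compound 3 to compound 4 (0.32 log units; beyond the scatter). Compound 4 is estimated at 30 nM, with a range of 8 nM to 120 nM.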

Compound 4, half-maximal inhibitory concentration: 74 nM
Beside the measured number, compound 4's estimate is 2.5-fold (0.39 log units) below it; low and high end bracket the measured number.
By their numbers in this assay, from the lowest: compounds 2 and 1 (each within the scatter of the next); then compounds 3 and 4 (each within the scatter of the next).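

Placing 1-(methoxymethyl)propyl in place of 1-methylbutyl on an aromatic nitrogen gives a 1.2-fold higher number from compound 3 to compound 4 (0.08 log units; within the scatter) in this assay, so the two compounds cannot be told apart. At this position, then, a chain carrying 1 hydrogen-bond acceptor reads the same as a chain with none, at least with the aryl group these two compounds share. Nothing measured here offers an explanation for this.

As far as these compounds go, it remains open whether the exchange would read the same with the aryl groups of compound 1 and compound 2. Also open, from the compounds shown here alone, is how a chain ending in an amine or a hydroxyl group would read at this position.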